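Replacing methoxy with tert-butyl in the series

The compounds below may be only part of what the source reports. "The series", "measured", "known", "first", "only" and "open" are said of these compounds alone.

Of the compounds shown here, three sharing one core have been measured, and they differ in a single aromatic substituent. In an ADME assay on HEp-2 cells (Homo sapiens) for cytotoxicity (a higher number here means that more compound is tolerated, a lower number that less compound is tolerated), compound 1 `Cc1ccc(Cl)cc1NC(=O)[C@@H]1CCCN1S(=O)(=O)c1cccc2cccnc12` gives 10000 nM, compound 2 `Cc1ccc(C(F)(F)F)cc1NC(=O)[C@@H]1CCCN1S(=O)(=O)c1cccc2cccnc12` gives 4800 nM and compound 3 `COc1ccc(C)c(NC(=O)[C@@H]2CCCN2S(=O)(=O)c2cccc3cccnc23)c1` gives 44200 nM. Compound 3 stands highest of the three. The chloro and trifluoromethyl compounds both sit under it, as a 4.4-fold higher number from compound 1 to compound 3 (0.65 log units; beyond the scatter) and a 9.2-fold higher number from compound 2 to compound 3 (0.96 log units; beyond the scatter) show. Between those two lies the smaller 2.1-fold lower number from compound 1 to compound 2 (0.32 log units; beyond the scatter).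

The next case is compound 4 `Cc1ccc(C(C)(C)C)cc1NC(=O)[C@@H]1CCCN1S(=O)(=O)c1cccc2cccnc12`, which carries tert-butyl in place of methoxy on an aromatic carbon. Going by the values given here, no tert-butyl compound has been measured, so the expectation rests on analogy with the two steps that end at methoxy. Read in reverse, compound 1 with a 4.4-fold higher number from compound 1 to compound 3 (0.65 log units; beyond the scatter) and compound 2 with a 9.2-fold higher number from compound 2 to compound 3 (0.96 log units; beyond the scatter) each show a fall in this assay when methoxy is absent. A fall of similar size is therefore expected here, and the expected step is a 7.4-fold lower number from compound 3 to compound 4 (0.87 log units; beyond the scatter). The estimated value for compound 4 is 6000 nM, with an expected range of 2000 nM to 20000 nM.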

Compound 4, half-maximal cytotoxic concentration: 6500 nM
Compound 4: the middle estimate sits 1.1-fold (0.03 log units) below what was measured; low and high end bracket the measured number.
By their numbers in this assay, from the lowest: compounds 2, 4 and 1 (each within the scatter of the next, the first and the last beyond it); then compound 3.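

The tert-butyl result extends the picture beyond halogen-bearing groups: in this assay, a substituent of carbon only also ends under the methoxy compound (a 6.8-fold lower number from compound 3 to compound 4 (0.83 log units; beyond the scatter)), so among these four compounds methoxy alone stands apart at this position, and none goes against that. Compound 4 cannot be separated from either of the other two (a 1.4-fold higher number from compound 2 to compound 4 (0.13 log units; within the scatter); a 1.5-fold lower number from compound 1 to compound 4 (0.19 log units; within the scatter)), even though the gap between those two is just beyond the scatter (a 2.1-fold lower number from compound 1 to compound 2 (0.32 log units; beyond the scatter)), so chloro, trifluoromethyl and tert-butyl form one loose group rather than a clear order. No available evidence bears on why the methoxy compound stands apart.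

The step from methoxy to tert-butyl removes the oxygen and its hydrogen-bond acceptor and also raises the heavy-atom count, and these compounds do not separate those changes from one another. Still open, from the compounds shown here alone, is whether the higher number belongs to methoxy alone or extends to other groups at this position, such as ethoxy, a hydroxyl, a dimethylamino group or a carboxylic acid.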